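Shortening and Branching the Amide Chain on a Shared Core

The source may report more compounds than this note shows. Statements on the series, on what has been measured and on what is new or still open speak of the compounds shown alone.

Within the data shown here, compound 2 `CCCCCC(=O)Nc1ccc(S(=O)(=O)Oc2ccccc2C(C)C)cc1` sits highest of the two numbers measured so far in a functional assay on HT-29 cells (Homo sapiens) for antiproliferative activity, read by sulforhodamine B assay, with a stated time of 48 h (on this read-out lower numbers stand for stronger inhibition and higher numbers for weaker inhibition), where compound 2 gives 6400 nM. Its nearest neighbour is compound 1 `CCCC(=O)Nc1ccc(S(=O)(=O)Oc2ccccc2C(C)C)cc1`, which in this assay gives 4900 nM. Compound 3 `CC(C)C(=O)Nc1ccc(S(=O)(=O)Oc2ccccc2C(C)C)cc1` differs from compound 2 by isopropyl in place of pentyl on a carbonyl carbon. Among the measured compounds shown here, the only measured step that bears on this change is the one that lengthened the same chain, a 1.3-fold higher number from compound 1 to compound 2 (0.12 log units; within the scatter), a change that stayed within the scatter; shortening the chain and branching it have not been tested directly. Because a 1.3-fold higher number from compound 1 to compound 2 (0.12 log units; within the scatter) shows that altering this chain by adding carbon left the number essentially unchanged, the expectation for compound 3 in this assay is a step of a 1.3-fold lower number from compound 2 to compound 3 (0.11 log units; within the scatter) that also stays within the scatter, with no preferred direction. Compound 3 is therefore estimated at 5000 nM, with a range from 2000 nM to 12000 nM.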

Compound 3, half-maximal inhibitory concentration: 14000 nM
Estimate against measurement, compound 3: 2.8-fold (0.45 log units) below; the measured number lies above the stated range.
By their numbers in this assay, from the lowest: compounds 1 and 2 (each within the scatter of the next); then compound 3.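

Among these compounds, on the carbonyl carbon of this amide, swapping one straight chain for another had so far moved nothing beyond the scatter in this assay, but isopropyl in place of pentyl gives a 2.2-fold higher number from compound 2 to compound 3 (0.34 log units; beyond the scatter) and isopropyl in place of propyl gives a 2.9-fold higher number from compound 1 to compound 3 (0.46 log units; beyond the scatter) as well. Both steps are modest yet beyond the scatter and point the same way, toward weaker inhibition, so this position does respond to the group it carries, and among these three compounds the one branched chain stands apart from the two straight ones. Nothing available explains why isopropyl differs from the straight chains here.

With a single branched group shown, it stays open whether branching itself matters or only this particular group. A tert-butyl, a cyclopropyl or a chain ending in an amine or a carboxylic acid on this carbonyl carbon would test how far the pattern extends.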